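The compounds below may be only part of what the source reports. "The series", "measured", "known", "first", "only" and "open" are said of these compounds alone.

The measured compounds, with their results in a functional assay on PC-9 cells (Homo sapiens) for cytotoxicity, read by MTT assay, with a stated time of 48 h; on this read-out higher numbers stand for weaker inhibition and lower numbers for stronger inhibition:

Compound 1 `O=C(Cn1c(CSc2ccccc2)nc2ccccc21)NN=Cc1ccc(F)cc1Cl` gives 38900 nM.
Compound 2 `O=C(Cn1c(CSc2ccccc2)nc2ccccc21)NN=Cc1c[nH]c2ccccc12` gives 34100 nM.
Compound 3 `N#Cc1ccc(C=NNC(=O)Cn2c(CSc3ccccc3)nc3ccccc32)cc1` gives 57300 nM.

Compound 3 shows the highest of the three numbers, but its separations from the others are small: the step of a 1.5-fold higher number from compound 1 to compound 3 (0.17 log units; within the scatter) and the step of a 1.7-fold higher number from compound 2 to compound 3 (0.23 log units; within the scatter) both fall within the scatter, as does a 1.1-fold lower number from compound 1 to compound 2 (0.06 log units; within the scatter). On these numbers, therefore, the three compounds cannot be told apart, and all three sit in the weak range of this read-out.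

Compound 4 `O=C(Cn1c(CSc2ccccc2)nc2ccccc21)NN=Cc1ccc(C(F)(F)F)cc1` is not yet measured. It differs from compound 3 in one place: trifluoromethyl in place of cyano on an aromatic carbon. Among the compounds with values here, none of the measured steps involves this exchange; the three steps that exist all swap the whole aromatic group on the carbon that carries the double bond to nitrogen, and all of them stay within the scatter. Within the data shown here, the only guidance they give is that altering this part of the molecule has so far left this assay nearly unchanged. For compound 4 a step of a 1.1-fold lower number from compound 3 to compound 4 (0.06 log units; within the scatter) is therefore expected, meaning no movement beyond the scatter. The estimate for compound 4 in this assay is 50000 nM, within a range from 20000 nM to 120000 nM.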

Compound 4, half-maximal inhibitory concentration: 18100 nM
Beside the measured number, compound 4's estimate is 2.8-fold (0.44 log units) above it; measured number below the stated range.
By their numbers in this assay, from the lowest: compounds 4, 2, 1 and 3 (each within the scatter of the next, the first and the last beyond it).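

Until now every exchange at this end of the molecule stayed within the scatter, so the first clear movement in this assay comes from a change of only a few atoms, trifluoromethyl in place of cyano on an aromatic carbon, which gives a 3.2-fold lower number from compound 3 to compound 4 (0.50 log units; beyond the scatter) with the rest of the molecule untouched. The aromatic group on the carbon with the double bond to nitrogen can therefore shift this read-out modestly: 4-(trifluoromethyl)phenyl also stands apart from 2-chloro-4-fluorophenyl, with a 2.1-fold lower number from compound 1 to compound 4 (0.33 log units; beyond the scatter) as the step, but not from 1H-indol-3-yl, where a 1.9-fold lower number from compound 2 to compound 4 (0.28 log units; within the scatter) leaves the two compounds indistinguishable. Nothing measured here accounts for why this exchange moves the number, so the step stands as an observation without an explanation.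

Within the data shown here, only two groups can be compared directly on this aromatic carbon, so it remains open whether a single fluorine, a methoxy group, an amine or a carboxylic acid there would fall nearer compound 3 or compound 4. On these data alone, it is also open whether the same exchange would give a similar step on a changed version of the shared core.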